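The compounds below may be only part of what the source reports. "The series", "measured", "known", "first", "only" and "open" are said of these compounds alone.

Measured compounds in an assay on Sf9 cells for inhibition of protein deacetylase HDAC6 (Homo sapiens), read by fluorescence; on this read-out higher numbers stand for weaker inhibition and lower numbers for stronger inhibition:
- compound 1 `O=C(NO)c1ccc(Cn2nnc(-c3ccc(S(F)(F)(F)(F)F)cc3)n2)cc1`: 25 nM
- compound 2 `O=C(NO)c1ccc(Cn2nnc(-c3ccccn3)n2)cc1`: 9 nM
- compound 3 `O=C(NO)c1ccc(Cn2nnc(-c3ncccn3)n2)cc1`: 7 nM

Compound 3 gives the lowest of the three numbers in this assay. Its nearest neighbour is compound 2, and the step of a 1.3-fold lower number from compound 2 to compound 3 (0.11 log units; within the scatter) lies within the scatter, so the two cannot be ordered. Compound 1 stands furthest away: compound 1 gives 25 nM, while compound 3 gives 7 nM, and the two values differ beyond the scatter.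

Compound 4 `O=C(NO)c1ccc(Cn2nnc(-c3ccccc3)n2)cc1` is not yet measured in this assay. It differs from compound 3 by phenyl in place of pyrimidin-2-yl on an aromatic carbon. Going by the values given here, the only measured step at this position is a 1.3-fold lower number from compound 2 to compound 3 (0.11 log units; within the scatter), which exchanged one six-membered aromatic ring with hetero atoms for another and was within the scatter. The pair compound 1 and compound 3 shows a larger gap, but compound 1 carries an additional pentafluorosulfanyl group on its phenyl, so that comparison does not isolate the ring exchange. On this basis a small step is expected, within or only slightly beyond the scatter, with the direction uncertain.

Compound 4 is therefore expected to give about 12 nM in this assay, with a range from 5 nM to 30 nM, meaning an expected step of a 1.7-fold higher number from compound 3 to compound 4 (0.23 log units; within the scatter).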

Compound 4, half-maximal inhibitory concentration: 3 nM
For compound 4 the middle estimate is 4.0-fold (0.60 log units) above the measured one; measured number below the stated range.
By their numbers in this assay, from the lowest: compound 4; then compounds 3 and 2 (each within the scatter of the next); then compound 1.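

In this assay, the ring on the aromatic carbon of the five-membered aromatic ring with 4 nitrogen now matters: the change to phenyl gives a 2.3-fold lower number from compound 3 to compound 4 (0.37 log units; beyond the scatter) and a 3.0-fold lower number from compound 2 to compound 4 (0.48 log units; beyond the scatter), whereas the exchange between the two rings with hetero atoms gave only a 1.3-fold lower number from compound 2 to compound 3 (0.11 log units; within the scatter). Among the compounds shown, the phenyl ring of carbon only therefore stands apart from both rings with hetero atoms, and compound 4 gives the lowest number of the series. The phenyl ring alone does not account for the higher number of compound 1, since replacing the pentafluorosulfanyl group with a hydrogen atom gives an 8.3-fold lower number from compound 1 to compound 4 (0.92 log units; beyond the scatter), and nothing available explains these steps.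

Hydrogen and pentafluorosulfanyl are the only two phenyl substituents shown, so it remains open whether a methyl, a fluorine or an amine on that ring would give numbers closer to compound 4 or to compound 1. Also open is whether a non-aromatic ring such as cyclohexyl at this position would match phenyl, and whether the order of these compounds would hold outside this assay.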